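Aryl ketone exchange on a shared core: compound 4 awaited

A few compounds are considered here, and "the series" means these few. Any claim that something is new, unique, unknown or untested is made for them only; others in the source may bear on it.

Compound 1 `COc1cc(-c2nnc3n2NC(c2ccco2)C(C(=O)c2cccc(Br)c2)S3)cc(OC)c1OC` is the reference point of the series. In a functional assay on HepG2 cells (Homo sapiens) for cytotoxicity, read by MTT assay, with a stated time of 48 h (on this read-out higher numbers stand for weaker inhibition and lower numbers for stronger inhibition), compound 1 gives only a limit, > 100000 nM. Compound 2 `COc1cc(-c2nnc3n2NC(c2ccco2)C(C(=O)c2ccccc2C)S3)cc(OC)c1OC` carries a 2-methylphenyl on the carbonyl carbon instead; in this assay compound 2 gives 63000 nM. Compound 3 `COc1cc(C(=O)C2Sc3nnc(-c4cc(OC)c(OC)c(OC)c4)n3NC2c2ccco2)cc(OC)c1OC` carries a 3,4,5-trimethoxyphenyl there. In this assay compound 3 likewise gives only a limit, > 100000 nM. The measured steps are an at least 1.5-fold lower number from compound 1 to compound 2 (0.20 log units; that floor lies within the scatter), an at least 1.5-fold higher number from compound 2 to compound 3 (0.20 log units; that floor lies within the scatter) and a step that the two limits leave unreadable from compound 1 to compound 3; the first two reach only a floor inside the scatter, and the limit of > 100000 nM in this assay, at which 2 of the 3 values shown sit, leaves the third unreadable. Compound 4 `COc1cc(-c2nnc3n2NC(c2ccco2)C(C(=O)c2ccc([N+](=O)[O-])cc2)S3)cc(OC)c1OC` differs from compound 1 by 4-nitrophenyl in place of 3-bromophenyl on a carbonyl carbon. All three measured steps are aryl exchanges on this same carbonyl carbon, and none of them shows a move beyond the scatter, so compound 4 is expected to sit in the same weak region, with a fair chance that this assay again returns only a limit. Compound 4 is therefore estimated at 100000 nM, with a range from 30000 nM to 300000 nM. The step this estimate implies is a number no higher from compound 1 to compound 4 (the limit leaves the size open).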

Compound 4, half-maximal inhibitory concentration: 87800 nM
The estimate for compound 4 lay 1.1-fold (0.06 log units) above the measured number; measured number inside the range.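

For the compounds shown here, for the first time, two aryl groups on this carbonyl carbon both give a readable number in this assay, and the result is a 1.4-fold higher number from compound 2 to compound 4 (0.14 log units; within the scatter), so 2-methylphenyl and 4-nitrophenyl cannot be told apart here. The steps involving the two compounds held at a limit reach only floors, an at least 1.1-fold lower number from compound 1 to compound 4 (0.05 log units; that floor lies within the scatter) and an at least 1.1-fold lower number from compound 3 to compound 4 (0.05 log units; that floor lies within the scatter), so neither 3-bromophenyl nor 3,4,5-trimethoxyphenyl can be set apart from 4-nitrophenyl. Any larger gap stays hidden for one reason: the limit of > 100000 nM in this assay, at which 2 of the 4 values shown sit.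

The compounds shown leave open whether any exchange on this carbonyl carbon can move the number beyond the scatter, for instance an amine or a carboxylic acid on the aryl group, or a longer chain in its place. They also leave open what a change elsewhere on the shared core would do.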